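The compounds below may be only part of what the source reports. "The series", "measured", "known", "first", "only" and "open" are said of these compounds alone.

Series notes. Compound 1 `CCN1CCCC(NC(=O)c2c(OC)cc(C(F)(F)F)cc2C(F)(F)F)(c2ccccc2)C1` gives 230 nM in an assay on cells for inhibition of sodium- and chloride-dependent glycine transporter 1 (Homo sapiens); on this read-out lower numbers stand for an effect already at smaller amounts and higher numbers for an effect only at larger amounts of compound. Compound 2 `COc1cc(C(F)(F)F)cc(C(F)(F)F)c1C(=O)NC1(c2ccccc2)CCCN(Cc2ccccc2)C1` gives 6700 nM in this assay, the step being a 29-fold higher number from compound 1 to compound 2 (1.46 log units; beyond the scatter). Compound 3 `CN1CCCC(NC(=O)c2ccc(C(F)(F)F)cc2)(c2ccccc2)C1` gives in this assay only a limit, > 10000 nM, sitting at the limit of > 10000 nM in this assay, at which 1 of the 3 values shown sits. Compound 4 `CN1CCCC(NC(=O)c2ccc(C(F)(F)F)cc2Br)(c2ccccc2)C1` differs from compound 3 by bromo in place of hydrogen on an aromatic carbon. Among the measured compounds shown here, no measured step alters a substituent on the aromatic ring of the amide; the single measured step concerns the group on the ring nitrogen and so does not bear on this change, and the direction of the step remains open. Compound 3 stands at a limit, so only a rough expectation follows. Compound 4 is expected to give roughly 6000 nM, within 1500 nM to 20000 nM. The expected step is an at least 1.6-fold lower number from compound 3 to compound 4 (0.22 log units; that floor lies within the scatter).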

Compound 4, half-maximal effective concentration: 300 nM
Estimate against measurement, compound 4: 20-fold (1.30 log units) above; the measured number lies below the stated range.
By their numbers in this assay, from the lowest: compounds 1 and 4 (each within the scatter of the next); then compound 2. At a limit, above all of these: compound 3.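

Bromo in place of hydrogen on this aromatic carbon, ortho to a large group and meta to a trifluoromethyl group, is the first measured change on the aromatic ring of the amide, and in this assay it gives an at least 33-fold lower number from compound 3 to compound 4 (1.52 log units; beyond the scatter). That size is only a floor, with compound 3 held at a limit: the limit of > 10000 nM in this assay, at which 1 of the 4 values shown sits.

So this ring position, and not only the group on the ring nitrogen, moves the read-out. Still open, from the compounds shown here alone, is whether the step belongs to bromo alone or also holds for chloro, methyl or a nitrile on this carbon.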